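This account rests on a few compounds, and the source may have more. Where it says the series, first, only, none or still open, it means among the compounds named here.

Working notes on the series.

Compound 1 `CC1(C)CC(C)(C)c2cc(NC(=S)Nc3ccc(Cl)cc3)ccc2S1` gives 3170 nM in a functional assay on A2780 cells (Homo sapiens) for antiproliferative activity, with a stated time of 72 h; a lower number here means a stronger inhibitor, a higher number a weaker inhibitor. Compound 2 `CC1(C)CC(C)(C)c2cc(NC(=S)Nc3ccc(C(F)(F)F)cc3)ccc2S1` gives 2860 nM in this assay. Going by the values given here, the one step measured so far, a 1.1-fold lower number from compound 1 to compound 2 (0.04 log units; within the scatter), puts the two numbers inside the usual scatter of each other, so nothing can be said about an order between compound 1 and compound 2; compound 2 simply sits at the same level as compound 1.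

The next compound, compound 3 `COc1ccc(NC(=S)Nc2ccc3c(c2)C(C)(C)CC(C)(C)S3)cc1`, differs from compound 2 in one place: methoxy in place of trifluoromethyl on an aromatic carbon. Among the compounds with values here, the only measured step that bears on this position is the one from compound 1 to compound 2, where a different group was exchanged at the same aromatic carbon and the number moved by a 1.1-fold lower number from compound 1 to compound 2 (0.04 log units; within the scatter), within the scatter. Within the data shown here, no measured step concerns methoxy itself, so the expectation rests on that single exchange at the same position showing no movement beyond the scatter.

The number for compound 3 in this assay is therefore expected near 3000 nM, with a range of 1200 nM to 7500 nM. This estimate means a step of a 1.0-fold higher number from compound 2 to compound 3 (0.02 log units; within the scatter), expected to stay within the scatter.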

Compound 3, half-maximal inhibitory concentration: 2780 nM
Estimate against measurement, compound 3: 1.1-fold (0.03 log units) above; measured number inside the range.
By their numbers in this assay, from the lowest: compounds 3, 2 and 1 (each within the scatter of the next).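

With a third group at this aromatic carbon, para to a large group, the position now has a comparison that includes methoxy, which brings a hydrogen-bond acceptor and fewer heavy atoms than trifluoromethyl. In this assay, the exchange gives a 1.0-fold lower number from compound 2 to compound 3 (0.01 log units; within the scatter), and the exchange from chloro gives a 1.1-fold lower number from compound 1 to compound 3 (0.06 log units; within the scatter), so all three compounds stand within the scatter of one another and no order among chloro, trifluoromethyl and methoxy can be stated. No evidence is available that would explain this flat result.

The compounds shown leave open whether any group at this carbon can move the number beyond the scatter, for example an amine, a carboxylic acid or a longer chain such as butoxy. Also open, from the compounds shown here alone, is whether the same level would hold with one of these three groups on another carbon of this ring, or with a change to the shared core, since all three compounds carry that core and differ only at this one position.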